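Swapping the Third Aryl Group on a Bis(hydroxyphenyl)pyridine Core

A few compounds are considered here, and "the series" means these few. Any claim that something is new, unique, unknown or untested is made for them only; others in the source may bear on it.

Measured compounds:
- compound 1 `Oc1cccc(-c2cc(-c3ccsc3)cc(-c3cccc(O)c3)n2)c1`: 1510 nM
- compound 2 `Oc1cccc(-c2cc(-c3ccco3)cc(-c3cccc(O)c3)n2)c1`: 3520 nM
- compound 3 `Oc1cccc(-c2cc(-c3ccoc3)cc(-c3cccc(O)c3)n2)c1`: 2590 nM

Three compounds share one core and differ only in the aromatic group attached opposite the ring nitrogen. In a functional assay on T47D cells (Homo sapiens) for cytotoxicity, read by CCK-8 assay (on this read-out higher numbers stand for weaker inhibition and lower numbers for stronger inhibition), compound 1 gives 1510 nM, compound 2 gives 3520 nM and compound 3 gives 2590 nM. Compound 3 sits second highest of the three numbers; its nearest neighbour is compound 2, its furthest compound 1, and the step in each direction, a 1.4-fold lower number from compound 2 to compound 3 (0.13 log units; within the scatter) and a 1.7-fold higher number from compound 1 to compound 3 (0.23 log units; within the scatter), lies within the scatter. Within the data shown here, only one step reaches beyond it, a 2.3-fold higher number from compound 1 to compound 2 (0.37 log units; beyond the scatter), and it is modest.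

Compound 4 `Oc1cccc(-c2cc(-c3ccccn3)cc(-c3cccc(O)c3)n2)c1` carries the change (pyridin-2-yl in place of furan-3-yl on an aromatic carbon). Among the measured compounds shown here, no measured step exchanges a five-membered ring for a six-membered one, so the three steps above bear on it only indirectly: all three ring swaps at this position moved this assay little. On that basis the expectation for compound 4 is a step no larger than the scatter, a 1.0-fold higher number from compound 3 to compound 4 (0.00 log units; within the scatter), with no firm direction. The estimated value for compound 4 is therefore 2600 nM, within a range of 1000 nM to 6500 nM.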

Compound 4, half-maximal inhibitory concentration: 1410 nM
Compound 4: middle estimate off by 1.8-fold (0.27 log units), on the high side, and the stated range covers the measured number.
By their numbers in this assay, from the lowest: compounds 4, 1, 3 and 2 (each within the scatter of the next, the first and the last beyond it).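

The pyridin-2-yl ring of compound 4 shows that a six-membered ring is tolerated at this position in this assay: its number cannot be told apart from that of the thiophen-3-yl compound (a 1.1-fold lower number from compound 1 to compound 4 (0.03 log units; within the scatter)) or from that of the furan-3-yl compound (a 1.8-fold lower number from compound 3 to compound 4 (0.26 log units; within the scatter)). Only the comparison with the furan-2-yl compound goes beyond the scatter (a 2.5-fold lower number from compound 2 to compound 4 (0.40 log units; beyond the scatter)), and that step is modest, so going from a five-membered to a six-membered ring widens the spread of the series only slightly, and compound 2 and compound 3 still cannot be told apart. Nothing available explains why these ring swaps change the number so little.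

As far as these compounds go, it remains open whether the ring nitrogen of pyridin-2-yl matters here at all, a question that a plain phenyl ring or a pyridin-4-yl group at the same position would address. Also open, from the compounds shown here alone, is whether this tolerance extends to a group of another kind, such as an amine or a carboxylic acid on that ring, and how much the two 3-hydroxyphenyl groups, constant throughout these compounds, contribute to the numbers.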